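This account rests on a few compounds, and the source may have more. Where it says the series, first, only, none or still open, it means among the compounds named here.

Three compounds with a shared core, each carrying 3-hydroxypiperidin-1-yl, have been measured in a functional assay on HCT-116 cells (Homo sapiens) for cytotoxicity, read by MTT assay, with a stated time of 72 h; a lower number here means a stronger inhibitor, a higher number a weaker inhibitor. Compound 1 (`O=S(=O)(c1ccccc1)c1nc2ccccc2nc1N1CCCC(O)C1`) gives 1390 nM, compound 2 (`COc1ccc(S(=O)(=O)c2nc3ccccc3nc2N2CCCC(O)C2)cc1`) gives 3520 nM, and compound 3 (`O=S(=O)(c1ccc(F)cc1)c1nc2ccccc2nc1N1CCCC(O)C1`) gives 5500 nM. The gaps show a 2.5-fold higher number from compound 1 to compound 2 (0.40 log units; beyond the scatter) and a 1.6-fold higher number from compound 2 to compound 3 (0.19 log units; within the scatter). Compound 2 therefore cannot be separated from compound 3, and both stand apart from compound 1, the strongest inhibitor of the three.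

Compound 4 (`COc1ccc(S(=O)(=O)c2nc3ccccc3nc2N2CCC(O)CC2)cc1`) is built from compound 2 by a single structural change: 4-hydroxypiperidin-1-yl in place of 3-hydroxypiperidin-1-yl on an aromatic carbon. The two compounds have the same atoms, joined differently.

Within the data shown here, none of the measured steps tests this change directly. Among the measured compounds shown here, each swaps hydrogen, methoxy or fluoro on an aromatic carbon, and no measured pair alters the hydroxypiperidinyl group. They offer only a rough sense of scale, the largest being a 4.0-fold higher number from compound 1 to compound 3 (0.60 log units; beyond the scatter), which is still modest. With no direct evidence for a shift in either direction, no step beyond the scatter is expected in this assay, although the uncertainty is wide. The expected change is a 1.0-fold lower number from compound 2 to compound 4 (0.00 log units; within the scatter). For compound 4 the estimated value is 3500 nM, with an expected range from 1200 nM to 10000 nM.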

Compound 4, half-maximal inhibitory concentration: 4690 nM
The estimate for compound 4 lay 1.3-fold (0.13 log units) below the measured number, and the stated range covers the measured number.
By their numbers in this assay, from the lowest: compound 1; then compounds 2, 4 and 3 (each within the scatter of the next).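

Until now, every measured step changed hydrogen, methoxy or fluoro on an aromatic carbon, so the hydroxypiperidinyl group on the aromatic carbon next to the ring nitrogen had not been tested at all. In this assay, replacing 3-hydroxypiperidin-1-yl with 4-hydroxypiperidin-1-yl gives a 1.3-fold higher number from compound 2 to compound 4 (0.12 log units; within the scatter), so this pair of isomers, which have the same atoms joined differently, cannot be told apart in this assay, and on the methoxy compounds the hydroxyl can occupy either ring position without a shift that exceeds ordinary measurement noise. Nothing available here offers an explanation for this result.

Still open is whether the hydroxyl is needed at all, as the compounds shown offer no comparison with a plain piperidine, a morpholine or a piperazine at this position, any of which would show whether the group tolerates a different ring or the loss of the hydroxyl. Also open, from the compounds shown here alone, is whether the same swap would read the same way with the hydrogen of compound 1 or the fluoro of compound 3 in place of the methoxy group.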